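Ethoxy to isopropoxy on a paw-edema amide series

The source may hold more compounds than are shown below. What is called first, only, known or untested is meant among the compounds shown, and "the series" means these compounds.

Measured compounds:
compound 1, `COc1cc(C(N)=O)nn1-c1ccccc1` — 34.3%
compound 2, `CCOc1cc(C(=O)N(C)C)nn1-c1ccccc1` — 65.8%

In a functional assay on the whole organism (strain Wistar) for inhibition, with Rattus norvegicus as the target, read by paw edema, with stated times of 30 min and 3 h, at a dose of 100 mg/kg by the oral route (on this read-out higher numbers stand for more inhibition at the one dose given (going by the name of the read-out) and lower numbers for less inhibition), compound 2 gives 65.8%, the higher of the two numbers recorded. Compound 1 gives 34.3% in this assay, and the gap to compound 2 is beyond the scatter of repeated measurements. For the measured compounds named here, the two compounds differ in more than one place, so no single step between them can be read off, and the values say only that compound 2 stands clearly higher.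

Compound 3, `CC(C)Oc1cc(C(=O)N(C)C)nn1-c1ccccc1`, has not yet been measured. It differs from compound 2 in one place: methyl in place of hydrogen on a saturated chain carbon bound to an oxygen on an aromatic ring and a saturated chain carbon. Going by the values given here, the only comparison available involves the same part of the molecule alongside a second change, so nothing here isolates what growing the alkoxy chain does on its own.

Among the compounds with values here, with no measured step of this kind, the expected change for compound 3 is modest, with no direction supported beyond the scatter; the step of a number 5.8 percentage points lower from compound 2 to compound 3 (within the scatter) is estimated to be small. Compound 3 is therefore expected to give about 60% in this assay, within a range from 40% to 78%.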

Compound 3, a percentage reported as inhibition, in the whole organism at one dose (the size of the read-out at that dose, not a potency): 43.9%
The estimate for compound 3 lay 16.1 percentage points above the measured number; the range from low to high includes it.
By their numbers in this assay, from the lowest: compounds 1 and 3 (each within the scatter of the next); then compound 2.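

In this assay, for the compounds shown here, the change from ethoxy to isopropoxy gives the first comparison at this alkoxy chain that differs in one place only: methyl in place of hydrogen on the saturated chain carbon bound to the oxygen gives a number 21.9 percentage points lower from compound 2 to compound 3 (beyond the scatter). This shows that the position is not indifferent to a single added methyl in this assay, something the earlier pair, differing in more than one place, could not show. The direction of this one step is downward with the dimethyl amide held fixed, but nothing available explains the drop.

From the compounds shown here alone, it remains open whether the drop follows from branching at this carbon or from the added carbon alone: a straight propoxy chain would separate the two, while a tert-butoxy group would extend the branching and a methoxy group on the same dimethyl amide would test the opposite direction. Going by these compounds, it also remains open whether the same ethoxy to isopropoxy step would give a similar change on the primary amide carried by compound 1.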